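Aryl amide change from compound 1 to compound 4

The compounds below may be only part of what the source reports. "The series", "measured", "known", "first", "only" and "open" are said of these compounds alone.

Measured in an ADME assay on BaF3 cells (Mus musculus) for antiproliferative activity, read by CellTiter-Glo and CCK-8 assay, with a stated time of 72 h; on this read-out higher numbers stand for weaker inhibition of growth and lower numbers for stronger inhibition of growth:
- compound 1 `CNc1nc(Nc2ccc(C)c([N+](=O)[O-])c2)ncc1C(=O)Nc1cc(NC(=O)c2cccc(C(F)(F)F)c2)ccc1C`: > 10000 nM (a limit)
- compound 2 `Cc1ccc(NC(=O)c2cccc(C(F)(F)F)c2)cc1NC(=O)c1cnc(Nc2ccc(C)c([N+](=O)[O-])c2)nc1`: 8700 nM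
- compound 3 `CNc1nc(Nc2ccc(C)c(N)c2)ncc1C(=O)Nc1cc(NC(=O)c2cccc(C(F)(F)F)c2)ccc1C`: > 10000 nM (a limit)

Compound 1 stands at the limit of > 10000 nM in this assay, at which 2 of the 3 values shown sit. Compound 4 `CNc1nc(Nc2ccc(C)c([N+](=O)[O-])c2)ncc1C(=O)Nc1cc(NC(=O)c2ccc(OC)cc2)ccc1C` differs from compound 1 as follows: 4-methoxyphenyl in place of 3-(trifluoromethyl)phenyl on a carbonyl carbon. The measured steps change other groups. The step of an at least 1.1-fold lower number from compound 1 to compound 2 (0.06 log units; that floor lies within the scatter) has a floor within the scatter, and the step that the two limits leave unreadable from compound 1 to compound 3 cannot be read. Neither changes the group on the carbonyl carbon, so neither gives a size for this change, and no step beyond the scatter is expected in this assay. The expected step is a number no higher from compound 1 to compound 4 (the limit leaves the size open). For compound 4 the estimate is 10000 nM, with an expected range from 3000 nM to 20000 nM.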

Compound 4, concentration for 50% growth inhibition: > 10000 nM
Compound 4 was reported as a limit (the forecaster's own chance of this, stated with the estimate: 65%); the middle value sits exactly at the limit.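

No step from compound 1 to compound 4 can be read in this assay, because both values are limits: the limit of > 10000 nM in this assay, at which 3 of the 4 values shown sit.

The compounds shown leave open how 4-methoxyphenyl and 3-(trifluoromethyl)phenyl on this carbonyl carbon compare in growth inhibition.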